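Solubility notes: the step from compound 2 to compound 4

A few compounds are considered here, and "the series" means these few. Any claim that something is new, unique, unknown or untested is made for them only; others in the source may bear on it.

Compound 1 `CN(C)C1(C)CN(c2c(F)cc3c(=O)c(C(=O)O)cn(C4CC4)c3c2F)C1`, compound 2 `CN[C@H]1CN(c2c(F)cc3c(=O)c(C(=O)O)cn(C4CC4)c3c2F)[C@@H]1C` and compound 3 `CN[C@H]1CN(c2cc3c(cc2F)c(=O)c(C(=O)O)cn3C2CC2)[C@@H]1C` share one core and have all been measured in a physicochemical assay for solubility, at pH 7.4; on this read-out lower numbers stand for lower solubility and higher numbers for higher solubility. Compound 1 gives 23.6 ug/mL, compound 2 gives 13.1 ug/mL and compound 3 gives 9.2 ug/mL. Compound 2 thus sits between its two neighbours on the numbers, but the step of a 1.8-fold lower number from compound 1 to compound 2 (0.26 log units; within the scatter) and the step of a 1.4-fold lower number from compound 2 to compound 3 (0.15 log units; within the scatter) both leave it within the scatter of them, so no ordering among the three is supported.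

Compound 4 `C[C@H]1[C@H](N)CN1c1c(F)cc2c(=O)c(C(=O)O)cn(C3CC3)c2c1F` is not yet measured. Its change from compound 2 is a group of 6 heavy atoms (4 carbon, 2 nitrogen; one four-membered non-aromatic ring with 1 hetero atom) in place of a group of 7 heavy atoms (5 carbon, 2 nitrogen; one four-membered non-aromatic ring with 1 hetero atom), on an aromatic carbon. Among the compounds with values here, the only measured step at the same position is a 1.8-fold lower number from compound 1 to compound 2 (0.26 log units; within the scatter); the step of a 1.4-fold lower number from compound 2 to compound 3 (0.15 log units; within the scatter) concerns a fluoro on the core and does not bear on the present change. Trimming the substituent on the four-membered ring gave no step beyond the scatter before, so none beyond the scatter is expected here either, at most a slight downward drift of a 1.1-fold lower number from compound 2 to compound 4 (0.04 log units; within the scatter). Compound 4 is therefore estimated at 12 ug/mL in this assay, with a range from 5 ug/mL to 28 ug/mL.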

Compound 4, solubility: 23.2 ug/mL
Beside the measured number, compound 4's estimate is 1.9-fold (0.29 log units) below it; the measured number falls inside the stated range.
By their numbers in this assay, from the lowest: compounds 3, 2, 4 and 1 (each within the scatter of the next, the first and the last beyond it).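

Notes on the result: in this assay the step of a 1.8-fold higher number from compound 2 to compound 4 (0.25 log units; within the scatter) joins the earlier step of a 1.8-fold lower number from compound 1 to compound 2 (0.26 log units; within the scatter) as a second reading at this aromatic carbon, and although the entering group has fewer heavy atoms in both cases, the two steps carry opposite signs, so no trend with group size is supported among compounds 1, 2 and 4. The step of a 1.0-fold lower number from compound 1 to compound 4 (0.01 log units; within the scatter) adds that the groups with the largest and smallest heavy-atom counts in this set cannot be told apart on this read-out, so all three groups on the four-membered ring lie within the scatter of one another. No available evidence bears on the result.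

On these data alone, all three compounds retain the four-membered non-aromatic ring at this position, so it remains open whether an open-chain amine there, or a hydroxyl group on that ring, would give a step beyond the scatter in this assay. Also open, as far as these compounds go, is whether the step between the groups of compound 2 and compound 4 would hold with hydrogen in place of the fluoro group on the core.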